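From Halogenated Phenyl to Benzothiazolyl on the Amide Nitrogen

A few compounds are considered here, and "the series" means these few. Any claim that something is new, unique, unknown or untested is made for them only; others in the source may bear on it.

Compound 1 `O=C(COc1ccc2cc(/C=C3/SC(=O)NC3=O)ccc2c1)Nc1cc(Cl)cc(C(F)(F)F)c1` gives > 50000 nM in an assay on isolated protein for inhibition of histone deacetylase 8 (Homo sapiens), with a stated time of 1 h (a higher number here means a weaker inhibitor, a lower number a stronger inhibitor), which is a limit of the assay and not a number.
Compound 2 `O=C(COc1ccc2cc(/C=C3/SC(=O)NC3=O)ccc2c1)Nc1ccc(Br)cc1F` gives > 50000 nM in this assay, again a limit of the assay.

Compound 2 therefore stands at the limit on the only numbers shown, with no measured value to separate it from compound 1. Among the measured compounds shown here, the single measured step, a step that the two limits leave unreadable from compound 1 to compound 2, cannot be read, since both of its ends are limits. The evidence is the limit of > 50000 nM in this assay, at which 2 of the 2 values shown sit.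

Compound 3 `Cc1cccc2sc(NC(=O)COc3ccc4cc(/C=C5/SC(=O)NC5=O)ccc4c3)nc12` has not yet been measured in this assay. It differs from compound 2 by 4-methyl-1,3-benzothiazol-2-yl in place of 4-bromo-2-fluorophenyl on an amide-type nitrogen. For the measured compounds named here, no measured step bears readably on this change, so no size or direction can be drawn from compound 1 or compound 2 beyond their shared limit. The account expects compound 3 to remain near that limit, with an estimated step of a number no higher from compound 2 to compound 3 (the limit leaves the size open). The estimated value of compound 3 in this assay is 50000 nM, expected to lie between 10000 nM and 100000 nM.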

Compound 3, half-maximal inhibitory concentration: 5800 nM
Estimate against measurement, compound 3: 8.6-fold (0.94 log units) above, outside the stated range (below it).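

With 4-methyl-1,3-benzothiazol-2-yl on the amide-type nitrogen, the series gives its first measured value in this assay, and this change can be read as an at least 8.6-fold lower number from compound 2 to compound 3 (0.93 log units; beyond the scatter). The same group in place of 3-chloro-5-(trifluoromethyl)phenyl gives an at least 8.6-fold lower number from compound 1 to compound 3 (0.93 log units; beyond the scatter), so the change reads in the same direction from either phenyl compound, while the step between those two compounds still cannot be read. Both steps have a limit at one end, and the two phenyl compounds remain at that limit of the assay: the limit of > 50000 nM in this assay, at which 2 of the 3 values shown sit.

The compounds shown leave open whether the step belongs to the two-ring benzothiazolyl group itself or to its 4-methyl group. A plain 1,3-benzothiazol-2-yl without the methyl, or a single-ring pyridin-2-yl on the same nitrogen, would bear on that question.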